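The source may hold more compounds than are shown below. What is called first, only, known or untested is meant among the compounds shown, and "the series" means these compounds.

The measured compounds:
Compound 1, `CCCCNc1nc(N)nc2ccn(Cc3ccccc3)c12`, gives > 24000 nM in an ADME assay on HEK293 cells (Homo sapiens) for cytotoxicity, read by ATP content, with a stated time of 6 h; a lower number here means that less compound is tolerated, a higher number that more compound is tolerated; this is a limit of the assay, not a number.
Compound 2, `CCCCNc1nc(N)nc2ccn(Cc3ccsc3)c12`, gives > 24000 nM in this assay; again only a limit.
Compound 3, `CCCCNc1nc(N)nc2ccn(Cc3ccncc3)c12`, gives > 24000 nM in this assay; again only a limit.

Compound 1 therefore stands at the top of what this assay can report, and so do both of its neighbours: the limit of > 24000 nM in this assay, at which 3 of the 3 values shown sit. The three compounds share one core and differ only in the aromatic ring hanging from a saturated chain carbon bound to an aromatic nitrogen. The step that the two limits leave unreadable from compound 1 to compound 2 cannot be sized, nor can a step that the two limits leave unreadable from compound 1 to compound 3 or a step that the two limits leave unreadable from compound 2 to compound 3, since every value involved is a limit.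

The unmeasured compound 4 is `CCCCNc1nc(N)nc2ccn(Cc3cccc(C)n3)c12`. Its change from compound 1 is 6-methylpyridin-2-yl in place of phenyl on a saturated chain carbon bound to an aromatic nitrogen. The three measured steps bear on it closely, as each also exchanges the ring at that same carbon, and none of them moved any compound off the limit. The expectation for compound 4 in this assay is therefore that it too sits at the limit, with a step that the limit leaves unreadable from compound 1 to compound 4 expected to show nothing beyond the scatter. Compound 4 is estimated at 40000 nM, with a range from 15000 nM to 150000 nM.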

Compound 4, half-maximal cytotoxic concentration: > 24000 nM
Compound 4: only a limit was reported (the forecaster's own chance of this, stated with the estimate: 85%); the middle value is on the limit's open side.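

In this assay compound 4 gives > 24000 nM, again only a limit. Its steps from compound 1, compound 2 and compound 3 therefore cannot be read. All four compounds stand at the same place: the limit of > 24000 nM in this assay, at which 4 of the 4 values shown sit.

The compounds shown leave open how far each lies beyond that limit, and whether any ring at this carbon gives a readable value.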